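The source may hold more compounds than are shown below. What is called first, only, known or untested is meant among the compounds shown, and "the series" means these compounds.

Compound 1 `CCc1nn2c(-c3cc(OC)c(OC)cc3OC)cccc2c1N(CC1CCOCC1)CC1CC1`: 130 nM
Compound 2 `COCc1cc(OC)c(-c2cccc3c(N(CC4CCOCC4)CC4CC4)c(C#N)nn23)c(OC)c1`: 52 nM

Both were tested in an assay on HEK293 cells for displacement of a labelled ligand from corticotropin-releasing factor receptor 1 (Homo sapiens), read by scintillation counting, with a stated time of 2 h; on this read-out higher numbers stand for weaker inhibition and lower numbers for stronger inhibition. Of the two, compound 2 gives the lower number, 52 nM, while compound 1 gives 130 nM; the gap between them lies beyond the usual scatter. Compound 3 `COCc1cc(OC)c(-c2cccc3c(N(CC4CCOCC4)CC4CC4)c(OC)nn23)c(OC)c1` has not yet been measured. It differs from compound 2 in one place: methoxy in place of cyano on an aromatic carbon. Among the measured compounds shown here, no measured pair shows this particular change, so its effect is unknown from these data. The step of a 1.7-fold higher number from compound 2 to compound 3 (0.24 log units; within the scatter) in this assay is expected to be small, toward slightly weaker inhibition if anything. Compound 3 is therefore estimated at 90 nM, with a range from 30 nM to 300 nM.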

Compound 3, half-maximal inhibitory concentration in the corticotropin-releasing factor receptor 1 assay: 51 nM
The estimate for compound 3 lay 1.8-fold (0.25 log units) above the measured number; the range from low to high includes it.
By their numbers in the corticotropin-releasing factor receptor 1 assay, from the lowest: compounds 3 and 2 (each within the scatter of the next); then compound 1.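

In the corticotropin-releasing factor receptor 1 assay, methoxy in place of cyano on this aromatic carbon, next to the ring nitrogen, gives a 1.0-fold lower number from compound 2 to compound 3 (0.01 log units; within the scatter), so the position accepts either group without a difference beyond the scatter. In a physicochemical assay for solubility, in phosphate buffer, measured as kinetic solubility (on this read-out lower numbers stand for lower solubility and higher numbers for higher solubility), the same change does separate the pair, with the methoxy compound giving the higher solubility: the measured solubility of compound 2, 1700 nM, and of compound 3, 5500 nM, a 3.2-fold higher number (0.51 log units; beyond the scatter) In the physicochemical assay, compound 2 gives 1700 nM and compound 3 gives 5500 nM.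

This single pair compares only these two groups with the rest of the molecule held fixed. Going by these compounds, whether an amine, a carboxylic acid or a longer alkoxy chain at this position would also leave the receptor read-out in place remains open.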